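Methyl in place of fluoro on an indanone-type chalcone

A few compounds are considered here, and "the series" means these few. Any claim that something is new, unique, unknown or untested is made for them only; others in the source may bear on it.

Three compounds have been measured in a functional assay on Molt4/C8 cells (Homo sapiens) for inhibition; a lower number here means a stronger inhibitor, a higher number a weaker inhibitor:

Compound 1 `O=C1/C(=C/c2ccc(Cl)c(Cl)c2)CCCc2ccccc21` gives 18200 nM.
Compound 2 `O=C1/C(=C/c2ccccc2F)Cc2ccccc21` gives 54200 nM.
Compound 3 `O=C1/C(=C/c2ccccc2[N+](=O)[O-])CCc2ccccc21` gives 8120 nM.

Among these three numbers compound 2 stands highest, and the gaps to compound 1 and to compound 3 both lie beyond the usual scatter, so compound 2 is the weakest inhibitor of the set.

Compound 4 `Cc1ccccc1/C=C1\Cc2ccccc2C1=O` has not yet been measured. It differs from compound 2 in one place: methyl in place of fluoro on an aromatic carbon. Among the compounds with values here, no pair of measured compounds shows this kind of change, so there is no direct precedent for its size or direction in this assay. A swap of two small uncharged groups of one heavy atom each would be expected to move the number little, if at all beyond the scatter, and the estimated step from compound 2 to compound 4 is a 1.4-fold lower number from compound 2 to compound 4 (0.13 log units; within the scatter). Compound 4 is therefore expected to give about 40000 nM, within a range from 15000 nM to 110000 nM.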

Compound 4, half-maximal inhibitory concentration: 154000 nM
Estimate against measurement, compound 4: 3.9-fold (0.59 log units) below; the whole stated range lies below it.
By their numbers in this assay, from the lowest: compound 3; then compound 1; then compound 2; then compound 4.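

Replacing fluoro with methyl on this aromatic carbon in this assay gives a 2.8-fold higher number from compound 2 to compound 4 (0.45 log units; beyond the scatter), the first one-place step available in this series. It shows that this position, ortho to a large group, can distinguish between two groups of one heavy atom each, neither with hydrogen-bond donors or acceptors and neither with a net charge, and that here methyl goes with the weaker inhibition. No measurement shown bears on why the number rises.

The compounds shown leave open how an unsubstituted hydrogen, a chloro or a methoxy group would fare on this same carbon. They also leave open whether methyl in place of fluoro would move the number the same way on the cores of compound 1 and compound 3.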